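Furan-2-yl to thiophen-2-yl at the end of the series

The source may hold more compounds than are shown below. What is called first, only, known or untested is meant among the compounds shown, and "the series" means these compounds.

In a functional assay on HeLa cells (Homo sapiens) for inhibition, with a stated time of 72 h (a higher number here means a weaker inhibitor, a lower number a stronger inhibitor), compound 1 (`NC1CCC(Nc2nc(NCc3ccc(Br)cc3)c3ncn(C4CCCC4)c3n2)CC1`) gives 1510 nM, compound 2 (`NC1CCC(Nc2nc(NCc3ccc(-c4ccsc4)cc3)c3ncn(C4CCCC4)c3n2)CC1`) gives 220 nM, and compound 3 (`NC1CCC(Nc2nc(NCc3ccc(-c4ccco4)nc3)c3ncn(C4CCCC4)c3n2)CC1`) gives 30 nM, the lowest of the three numbers. Compound 4 (`NC1CCC(Nc2nc(NCc3ccc(-c4cccs4)nc3)c3ncn(C4CCCC4)c3n2)CC1`) carries thiophen-2-yl in place of furan-2-yl on an aromatic carbon next to the ring nitrogen: thiophen-2-yl in place of furan-2-yl on an aromatic carbon. Going by the values given here, two measured steps touch this position: a 6.9-fold lower number from compound 1 to compound 2 (0.84 log units; beyond the scatter) and a 7.3-fold lower number from compound 2 to compound 3 (0.87 log units; beyond the scatter). Both are modest, but the second also changes the six-membered ring, so neither isolates this swap. The expected change is small, a 1.3-fold higher number from compound 3 to compound 4 (0.12 log units; within the scatter), and no step beyond the scatter is anticipated. For compound 4 the estimate is 40 nM, with an expected range of 15 nM to 110 nM.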

Compound 4, half-maximal inhibitory concentration: 40 nM
Beside the measured number, compound 4's estimate shows no gap at the digits printed, and the stated range covers the measured number.
By their numbers in this assay, from the lowest: compounds 3 and 4 (each within the scatter of the next); then compound 2; then compound 1.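

In this assay, the step confined to the five-membered aromatic ring gives a 1.3-fold higher number from compound 3 to compound 4 (0.12 log units; within the scatter), so at this aromatic carbon oxygen and sulfur in the ring cannot be told apart. Going by these compounds alone, compound 4 also keeps clear of the earlier compounds, with a 5.5-fold lower number from compound 2 to compound 4 (0.74 log units; beyond the scatter) and a 38-fold lower number from compound 1 to compound 4 (1.58 log units; beyond the scatter), so furan-2-yl is not required for the lower numbers of this pair. No supporting data accompany this result to account for it. Compound 2 and compound 4 differ in both the six-membered ring and the thiophene attachment, leaving those two changes unseparated. As far as these compounds go, whether an aminomethyl or carboxylic acid group on the thiophen-2-yl ring would be tolerated remains open.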